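A few compounds are considered here, and "the series" means these few. Any claim that something is new, unique, unknown or untested is made for them only; others in the source may bear on it.

Measured so far in a functional assay on NCI-H460 cells (Homo sapiens) for cytotoxicity, read by sulforhodamine B assay, with a stated time of 3 days; a higher number here means a weaker inhibitor, a lower number a stronger inhibitor:
compound 1, `O=Cc1cn(Cc2ccc(Cl)cc2)c2ccc(F)cc12`, 290 nM
compound 2, `O=Cc1cn(Cc2ccc(Cl)cc2)c2ccc(Cl)cc12`, 400 nM
compound 3, `OCc1cn(Cc2cccc(F)c2)c2ccccc12`, 40 nM

Compound 1 and compound 2 share one core and differ in a single place: chloro in place of fluoro on an aromatic carbon. The step between them is a 1.4-fold higher number from compound 1 to compound 2 (0.14 log units; within the scatter). Compound 3 is built on a different core; the difference between the two cores is not broken down here. In this assay compound 3 gives the lowest number of the three, and its gaps to compound 1 and to compound 2 both lie beyond the scatter.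

Compound 4, `OCc1cn(Cc2cccc(Cl)c2)c2ccccc12`, has not yet been measured. It differs from compound 3 in one place: chloro in place of fluoro on an aromatic carbon. Among the measured compounds shown here, this is the same kind of change as the one from compound 1 to compound 2, but not the same change: in compound 1 the fluoro sits on a ring that is part of a fused or bridged system of two rings, meta to a fused ring and para to a fused ring, whereas in compound 3 it sits on a six-membered aromatic ring of carbon only, meta to a large group. For the measured compounds named here, the single measured example of this kind of change stayed within the scatter, and nothing among the three measured compounds shows how the change behaves on the core of compound 3. The step from compound 3 to compound 4 is therefore expected to be small, a 1.4-fold higher number from compound 3 to compound 4 (0.14 log units; within the scatter), because the same kind of change gave a 1.4-fold higher number from compound 1 to compound 2 (0.14 log units; within the scatter). Compound 4 is estimated at 55 nM in this assay, with a likely range from 25 nM to 130 nM.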

Compound 4, half-maximal inhibitory concentration: 19 nM
Compound 4: the middle estimate sits 2.9-fold (0.46 log units) above what was measured; measured number below the stated range.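

In this assay, chloro in place of fluoro on a six-membered aromatic ring of carbon only, meta to a large group, gave a 2.1-fold lower number from compound 3 to compound 4 (0.32 log units; beyond the scatter) as a modest step. Among the compounds shown here, this does not show what sets the two outcomes apart: the pairs differ in their cores, and the change also sits on a different kind of ring in each, so neither difference can be singled out with only one pair on each core. What the comparison does show is that the result of this change on one core did not carry over to the other in this series: the same change on two cores in this assay, a 1.4-fold higher number (0.14 log units; within the scatter) from compound 1 to compound 2 and a 2.1-fold lower number (0.32 log units; beyond the scatter) from compound 3 to compound 4, 2.9-fold (0.46 log units) apart, beyond the scatter of two such steps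

The compounds shown leave open whether a bromo, a methyl or a methoxy group in the same place on the core of compound 4 would extend this step or reverse it. They also leave open how the same halogen change would behave if the hydroxymethyl group of compound 3 and compound 4 gave way to an amine or a carboxylic acid.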